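The compounds below may be only part of what the source reports. "The series", "measured", "known", "first", "only" and "open" are said of these compounds alone.

Measured so far in a functional assay on CHO cells for antagonist activity at adenosine receptor A2b (Homo sapiens), read by 33P incorporation, with a stated time of 20 min; a higher number here means a weaker inhibitor, a lower number a stronger inhibitor:
compound 1 `Cn1c(-c2ccc(F)cc2)nc2c(NC3CCCC3)ncnc21` gives > 30000 nM
compound 2 `CCn1c(-c2ccccc2)nc2c(NC3CCCCC3)ncnc21` gives 9020 nM.

For compound 1 the reported figure is only a limit of the assay, not a number (the limit of > 30000 nM in this assay, at which 1 of the 2 values shown sits). Compound 3 `Cn1c(-c2cccc(Cl)c2)nc2c(NC3CCCC3)ncnc21` has not yet been measured. It differs from compound 1 by 3-chlorophenyl in place of 4-fluorophenyl on an aromatic carbon, a 3-chlorophenyl in place of a 4-fluorophenyl on an aromatic carbon. Within the data shown here, no measured pair shows what this change does here, so any step in this assay is expected to be modest, likely within the scatter, with no clear direction. Compound 3 is expected to give 20000 nM, between 5000 nM and 60000 nM, meaning a step of an at least 1.5-fold lower number from compound 1 to compound 3 (0.17 log units; that floor lies within the scatter).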

Compound 3, inhibition constant: 2530 nM
The estimate for compound 3 lay 7.9-fold (0.90 log units) above the measured number; the whole stated range lies above it.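

In this assay, putting 3-chlorophenyl in place of 4-fluorophenyl on this aromatic carbon gives an at least 11-fold lower number from compound 1 to compound 3 (1.07 log units; beyond the scatter). The group at this position therefore matters, and the step is large even for two groups of equal heavy-atom count. The step has only a floor, as the figure for compound 1 is a limit of the assay, not a number: the limit of > 30000 nM in this assay, at which 1 of the 3 values shown sits.

This change moves the ring substituent and switches the halogen together, and the compounds shown do not separate the two. A 4-chlorophenyl or 3-fluorophenyl group would separate them, while an amine on the phenyl ring remains an open question.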